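Chlorine on the Benzyl Ring of a Chloroacetamide Series

The compounds below may be only part of what the source reports. "The series", "measured", "known", "first", "only" and "open" are said of these compounds alone.

Measured compounds and values:
Compound 1, `O=C(CSc1nc2ccc(NC(=O)CCl)cc2s1)NCc1ccccc1`: 4200 nM
Compound 2, `O=C(CSc1nc2ccc(NC(=O)c3ccccc3)cc2s1)NCc1ccccc1`: 35600 nM

In a functional assay on MCF7 cells (Homo sapiens) for cytotoxicity, read by MTT assay, with a stated time of 48 h (a lower number here means a stronger inhibitor, a higher number a weaker inhibitor), compound 1 gives 4200 nM, the lower of the two numbers. Compound 2 differs from it only at the carbonyl carbon of the anilide, where a phenyl replaces the chloromethyl, and this step gives an 8.5-fold higher number from compound 1 to compound 2 (0.93 log units; beyond the scatter).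

Compound 3 is `O=C(CSc1nc2ccc(NC(=O)CCl)cc2s1)NCc1ccc(Cl)cc1`. It keeps the chloromethyl and the whole shared core of compound 1 and changes only the benzyl end: chloro in place of hydrogen on an aromatic carbon. Among the measured compounds shown here, no measured pair shows this kind of change; the one step available, an 8.5-fold higher number from compound 1 to compound 2 (0.93 log units; beyond the scatter), alters a different part of the molecule, so it gives no direct guide to what a chloro on the benzyl ring does here. With nothing to point either way, the expectation is a step from compound 1 to compound 3 that stays within the scatter, a 1.2-fold lower number from compound 1 to compound 3 (0.08 log units; within the scatter), in this assay.

For compound 3, the estimated value in this assay is 3500 nM, with a likely range from 1200 nM to 10000 nM.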

Compound 3, half-maximal inhibitory concentration: 4900 nM
For compound 3 the middle estimate is 1.4-fold (0.15 log units) below the measured one, within the range that was stated.
By their numbers in this assay, from the lowest: compounds 1 and 3 (each within the scatter of the next); then compound 2.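

In this assay, chloro in place of hydrogen on the benzyl ring, para to a large group, gives a 1.2-fold higher number from compound 1 to compound 3 (0.07 log units; within the scatter), so the benzylamino and (4-chlorobenzyl)amino versions of this chloroacetamide cannot be told apart by this read-out. Among the compounds shown here, this is the first view of the benzyl end of the series, since the earlier step, an 8.5-fold higher number from compound 1 to compound 2 (0.93 log units; beyond the scatter), concerned the group on the anilide carbonyl and lay beyond the scatter, whereas this single added atom at the other end of the molecule does not. No supporting measurement is available to interpret this result.

One chloro at one ring position says little about other groups at this end: a methoxy, an amine or a carboxylic acid on the same ring, or a longer chain in place of the benzyl, could give quite different numbers. Also open, going by these compounds, is whether chloro would behave the same way at other carbons of that ring, or on the phenyl amide of compound 2 rather than on the chloromethyl amide.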